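The source may hold more compounds than are shown below. What is called first, only, known or untested is meant among the compounds shown, and "the series" means these compounds.

In a functional assay on CHO cells for agonist activity at Alpha-1A adrenergic receptor (Homo sapiens), read by FLIPR and calcium flux (on this read-out lower numbers stand for an effect already at smaller amounts and higher numbers for an effect only at larger amounts of compound), compound 1, with the structure `COCc1ccccc1C1Cc2nccn2C1`, gives 82 nM. Among the compounds with a single number in this assay, compound 1 stands lowest: the nearest is compound 2, `COc1cccc(C2CCc3nc[nH]c3C2)c1`, which gives 1050 nM, a gap beyond the usual scatter. Compound 3, `c1ccc(C2CCc3nc[nH]c3C2)cc1`, gives 234 nM; 123 nM; 315 nM (3 entries), known from several entries, (the several entries of compound 3 in this assay, 234 nM; 123 nM; 315 nM (3 entries)), and so offers no single number for comparison. The step considered here leads from compound 1 to compound 4, `NC(=O)c1ccccc1C1Cc2nccn2C1`; it is the exchange (carbamoyl in place of methoxymethyl on an aromatic carbon), carbamoyl in place of methoxymethyl on an aromatic carbon. Going by the values given here, no pair among the measured compounds shows this exchange, so the direction of the step is not known from the data at hand. Nothing else in the set changes between compound 1 and compound 4. The value of compound 4 in this assay is estimated at 220 nM, with a range from 50 nM to 900 nM; this estimate means a step of a 2.7-fold higher number from compound 1 to compound 4 (0.43 log units; beyond the scatter), expected to be a modest loss, though a result within the scatter of compound 1 is also possible.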

Compound 4, half-maximal effective concentration: 371 nM
For compound 4 the middle estimate is 1.7-fold (0.23 log units) below the measured one, and the stated range covers the measured number.
By their numbers in this assay, from the lowest: compound 1; then compound 4; then compound 2.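

In this assay, carbamoyl in place of methoxymethyl on this aromatic carbon gives a 4.5-fold higher number from compound 1 to compound 4 (0.66 log units; beyond the scatter), so the place takes a group with a hydrogen-bond donor and a double bond outside aromatic rings at a modest cost and a measurable effect remains. Going by these compounds alone, the earlier compounds held no step between measured compounds, so this is the first reading of how a single change at this place moves the number on the shared core. Nothing in the data at hand bears on why the step has this size.

Whether the loss follows the hydrogen-bond donor or the carbonyl stays open, as the compounds shown do not separate them. As far as these compounds go, how an amine, a carboxylic acid or a longer chain such as ethoxymethyl would read at this place also remains open.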